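Cyclopropyl for Propargyl on the Amide Nitrogen

The source may hold more compounds than are shown below. What is called first, only, known or untested is meant among the compounds shown, and "the series" means these compounds.

Compound 1: `C#CCNC(=O)/C(C)=C(\C)c1ccc(Br)cc1`, 150 mg/kg
Compound 2: `C#CCNC(=O)/C(C)=C(\C)c1ccc(C)cc1`, 150 mg/kg

In a toxicity assay on the whole organism (strain Icem-CET (SPF Caw)) for cytotoxicity, with Mus musculus as the target (a lower number here means that less compound is needed, a higher number that more compound is needed for the effect), compound 1 gives 150 mg/kg. Compound 2 gives 150 mg/kg in this assay. The one measured step, no change at the digits printed from compound 1 to compound 2 (within the scatter), lies within the scatter, so compound 2 stands level with compound 1 on the numbers shown.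

Compound 3 (`C/C(C(=O)NC1CC1)=C(/C)c1ccc(C)cc1`) differs from compound 2 by cyclopropyl in place of propargyl on an amide-type nitrogen. For the measured compounds named here, no measured step touches the amide-type nitrogen, and the only step known concerns a different place and showed no change. Compound 3 is therefore expected to show no step beyond the scatter, no change at the digits printed from compound 2 to compound 3 (within the scatter). The estimate for compound 3 is 150 mg/kg, with a range from 75 mg/kg to 300 mg/kg.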

Compound 3, dose for half-maximal effect: 150 mg/kg
Compound 3: middle estimate and measured number agree at the digits printed; the measured number falls inside the stated range.
By their numbers in this assay, from the lowest: compounds 1, 2 and 3 (each within the scatter of the next).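

The amide-type nitrogen now has a measured change of its own: in this assay there is no change at the digits printed from compound 2 to compound 3 (within the scatter) when cyclopropyl replaces propargyl. At this position, then, a triple bond outside aromatic rings gives way to a three-membered carbon ring, with the heavy-atom count unchanged, and the step stays within the scatter. Nothing available here explains this result.

From the compounds shown here alone, whether a longer chain or a carboxylic acid on this nitrogen would also leave the number level remains open. So does whether cyclopropyl would do the same with bromo in place of methyl on the aromatic carbon.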